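A few compounds are considered here, and "the series" means these few. Any claim that something is new, unique, unknown or untested is made for them only; others in the source may bear on it.

In a functional assay on MDA-MB-231 cells (Homo sapiens) for antiproliferative activity, read by sulforhodamine B assay, with a stated time of 48 h (a higher number here means a weaker inhibitor, a lower number a stronger inhibitor), compound 3 (`COc1cc(OC)c2sc(-c3ccc(N/C=C\C(=O)c4ccc(OC)c(F)c4)c(C)c3)nc2c1`) gives 13300 nM, within the scatter of compound 1 (`COc1cc(OC)c2sc(-c3ccc(N/C=C\C(=O)c4ccc(OC)c(O)c4)cc3)nc2c1`) at 7610 nM, whereas compound 2 (`COc1ccc(C(=O)/C=C\Nc2ccc(-c3nc4cc(OC)c(OC)c(OC)c4s3)cc2C)cc1F`) gives 2900 nM. Compound 4 (`COc1cc(OC)c2sc(-c3ccc(N/C=C\C(=O)c4ccc(OC)c(F)c4)cc3)nc2c1`) changes compound 3 in one place: hydrogen in place of methyl on an aromatic carbon. Among the compounds with values here, no measured step covers this exact change. Within the data shown here, the only one available, a 4.6-fold higher number from compound 2 to compound 3 (0.66 log units; beyond the scatter), concerns a methoxy rather than this methyl, so it shows only that one small swap can matter here. Compound 1 also lacks the methyl but carries hydroxy instead of fluorine, so its 7610 nM is only a loose guide. A small expected shift, within the scatter, is a 1.5-fold lower number from compound 3 to compound 4 (0.17 log units; within the scatter). For compound 4, the estimated value is 9000 nM, with an expected range of 3500 nM to 22000 nM.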

Compound 4, half-maximal inhibitory concentration: 6700 nM
Estimate against measurement, compound 4: 1.3-fold (0.13 log units) above, within the range that was stated.
By their numbers in this assay, from the lowest: compound 2; then compounds 4, 1 and 3 (each within the scatter of the next).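

In this assay, taking the methyl off this aromatic carbon gives a 2.0-fold lower number from compound 3 to compound 4 (0.30 log units; within the scatter), so, unlike the methoxy step measured earlier, this change does not separate the two compounds. Fluoro in place of hydroxy on the other aromatic ring gives a 1.1-fold lower number from compound 1 to compound 4 (0.06 log units; within the scatter), so that swap also shows no clear difference in this assay. No measured evidence here explains either result. Still open, going by these compounds, is whether an amine or a longer chain on this carbon would move the number beyond the scatter. Also open, on these data alone, is whether losing the methyl from compound 2 would give a similarly small step.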